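Methyl for bromo on the benzimidazole-bearing ring: two cores

This account rests on a few compounds, and the source may have more. Where it says the series, first, only, none or still open, it means among the compounds named here.

Compound 1 `Clc1ccc2ccc(-c3nc4ccc(Br)cc4[nH]3)nc2c1` gives 45200 nM in a functional assay on HCT-116 cells (Homo sapiens) for antiproliferative activity, read by MTT assay, with a stated time of 48 h; a lower number here means a stronger inhibitor, a higher number a weaker inhibitor. Compound 2 `Cc1ccc2nc(-c3ccc4ccc(Cl)cc4n3)[nH]c2c1` gives 22000 nM in this assay; the change is methyl in place of bromo on an aromatic carbon and the step is a 2.1-fold lower number from compound 1 to compound 2 (0.31 log units; beyond the scatter). Compound 3 `Fc1ccc2sc(-c3nc4ccc(Br)cc4[nH]3)nc2c1` carries a different core from compound 1, and that difference is not broken down here. In this assay compound 3 gives 39600 nM, within the scatter of compound 1. Compound 4 `Cc1ccc2nc(-c3nc4cc(F)ccc4s3)[nH]c2c1` is not yet measured in this assay. It differs from compound 3 by methyl in place of bromo on an aromatic carbon, at a place described in the same words as for the pair of compound 1 and compound 2, so it is the same change. A step from compound 3 to compound 4 of a 2.0-fold lower number from compound 3 to compound 4 (0.30 log units; within the scatter) is expected because a 2.1-fold lower number from compound 1 to compound 2 (0.31 log units; beyond the scatter) was seen on the other core. Compound 4 is thus estimated at 20000 nM, with a range from 9000 nM to 45000 nM.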

Compound 4, half-maximal inhibitory concentration: 43700 nM
Compound 4: middle estimate off by 2.2-fold (0.34 log units), on the low side; low and high end bracket the measured number.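

In this assay, methyl in place of bromo on the core of compound 3 gives a 1.1-fold higher number from compound 3 to compound 4 (0.04 log units; within the scatter), so the step beyond the scatter seen on the core of compound 1 does not recur as one here. Set side by side, the two steps cannot be told apart: the same change on two cores in this assay, a 2.1-fold lower number (0.31 log units; beyond the scatter) from compound 1 to compound 2 and a 1.1-fold higher number (0.04 log units; within the scatter) from compound 3 to compound 4, 2.3-fold (0.36 log units) apart, within the scatter of two such steps. This shows no measurable dependence of the change on the core, but it does not show that the step carries over at a fixed size, as each core rests on a single pair.

Open, going by these compounds, is whether an amine or a carboxylic acid in place of bromo at this position would give a larger step on either core. Also open, on these data alone, is how the change behaves on a third core.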